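The source may report more compounds than this note shows. Statements on the series, on what has been measured and on what is new or still open speak of the compounds shown alone.

Measured compounds:
Compound 1 `C=C1CC[C@@H]2[C@](C)(CO)[C@H](O)CC[C@@]2(C)[C@@H]1CCC1C(=O)OC[C@H]1O` — in a functional assay on BMMC cells (Mus musculus, strain C57BL/6) for inhibition, with stated times of 5 days and 48 h (on this read-out higher numbers stand for weaker inhibition and lower numbers for stronger inhibition), compound 1 gives > 30000 nM, a limit of the assay rather than a number.
Compound 2 `C=C1CC[C@@H]2[C@](C)(CO)[C@H](O)CC[C@@]2(C)[C@@H]1CC=O` — in this assay compound 2 gives > 30000 nM, again a limit.
Compound 3 `C=C1CC[C@@H]2[C@](C)(CNCc3ccc(OC)cc3)[C@H](O)CC[C@@]2(C)[C@@H]1/C=C/C1=CCOC1=O` — in this assay compound 3 gives 750 nM.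

Going by the values given here, compound 3 therefore stands as the only compound with an actual number; the other two sit at the limit described by the limit of > 30000 nM in this assay, at which 2 of the 3 values shown sit, so nothing finer can be said of them. Among the compounds with values here, the one step between measured compounds, a step that the two limits leave unreadable from compound 1 to compound 2, lies between two limits and its size cannot be read.

Compound 4 `C=C1CC[C@@H]2[C@](C)(CNCc3ccc(Br)cc3)[C@H](O)CC[C@@]2(C)[C@@H]1/C=C/C1=CCOC1=O` differs from compound 3 in a single place: bromo in place of methoxy on an aromatic carbon. No measured step touches this part of the molecule, and the only measured step at all is unreadable, so there is no guide from the shown data to the size or direction of this change. The step of no change at the digits printed from compound 3 to compound 4 (within the scatter) is therefore expected to be none beyond the usual scatter. Compound 4 is estimated at 750 nM, within a range of 300 nM to 2000 nM.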

Compound 4, half-maximal inhibitory concentration: 430 nM
Compound 4: the middle estimate sits 1.7-fold (0.24 log units) above what was measured; low and high end bracket the measured number.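

Going by these compounds alone, putting bromo in place of methoxy on this aromatic carbon gives a 1.7-fold lower number from compound 3 to compound 4 (0.24 log units; within the scatter) in this assay and is the first step that can be read as a number. It shows that, in this one pair, the position takes either group without a change beyond the scatter, even though the hydrogen-bond acceptor of the methoxy is gone. Nothing measured here accounts for this outcome.

Still open, as far as these compounds go, is whether the same holds for very different groups on this aromatic carbon, such as a hydroxyl, an amine or a carboxylic acid. Also open, from the compounds shown here alone, is what a plain amine in place of the whole (4-bromobenzyl)amino group would give on the same core.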